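Swapping the amide for a sulfonamide on the shared core

This account rests on a few compounds, and the source may have more. Where it says the series, first, only, none or still open, it means among the compounds named here.

Compound 2 `O=C(C1CCCCC1)N1CCc2nc(C#Cc3ccccc3)sc2C1` carries a cyclohexylcarbonyl group on the ring nitrogen of the shared core. Among the compounds with values here, in an assay on HEK293 cells for positive allosteric modulation of metabotropic glutamate receptor 5 (Homo sapiens), read by FLIPR, with a stated time of 1 h (on this read-out higher numbers stand for an effect only at larger amounts of compound and lower numbers for an effect already at smaller amounts), compound 2 gives 167 nM, the highest of the two numbers measured so far. Within the data shown here, its only neighbour is compound 1 `CC1CC1C(=O)N1CCc2nc(C#Cc3ccccc3)sc2C1`, which in this assay gives 9.4 nM; the change an 18-fold higher number from compound 1 to compound 2 (1.25 log units; beyond the scatter) shows that the size of the ring on the carbonyl carbon matters strongly. Compound 3 `O=S(=O)(C1CC1)N1CCc2nc(C#Cc3ccccc3)sc2C1` differs from compound 2 by cyclopropylsulfonyl in place of cyclohexylcarbonyl on an amine nitrogen in a ring. Among the measured compounds shown here, no measured step covers the exchange of a carbonyl for a sulfonyl, so only the ring-size step from compound 1 to compound 2 bears on it, and that step was large. Because of an 18-fold higher number from compound 1 to compound 2 (1.25 log units; beyond the scatter), a return to a three-membered ring is expected to lower the number, tempered by the untested sulfonyl. Compound 3 is estimated at 60 nM, in the range 10 nM to 400 nM, a step of a 2.8-fold lower number from compound 2 to compound 3 (0.44 log units; beyond the scatter).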

Compound 3, half-maximal effective concentration: > 10000 nM
Compound 3 was reported as a limit; the forecaster's own chance of this, stated with the estimate: 10%; middle value at least 160-fold (2.22 log units) from the limit.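

The three-membered ring of compound 1 does not carry the effect by itself, since compound 3 also has a three-membered ring on the same amine nitrogen in a ring. Exchanging the group there gives an at least 59-fold higher number from compound 2 to compound 3 (1.77 log units; beyond the scatter), and the comparison with the more active amide gives an at least 1000-fold higher number from compound 1 to compound 3 (3.02 log units; beyond the scatter). The reading of compound 3 in this assay is a limit of the assay, not a number: the limit of > 10000 nM in this assay, at which 1 of the 3 values shown sits.

Both steps change the ring and the link to the nitrogen together, so the share of the sulfonyl cannot be separated from that of the ring. A cyclohexylsulfonyl or methylsulfonyl group, or a urea or carbamate on this nitrogen, would show how much of the activity depends on the carbonyl link.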